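The source may report more compounds than this note shows. Statements on the series, on what has been measured and on what is new or still open speak of the compounds shown alone.

Measured compounds:
- compound 1, `CCCOC1=C(CCC)C(=O)/C(=C(O)/C=C/c2ccccc2)C(=O)C1(CCC)CCC`, 8.3 uM
- compound 2, `COC1=C(CCC(C)C)C(=O)/C(=C(O)/C=C/c2ccccc2)C(=O)C1(CCC(C)C)CCC(C)C`, "not active" (no number reported)
- compound 3, `CCCOC1=C(CCC)C(=O)/C(=C(O)/C=C/c2ccc(I)cc2)C(=O)C1(CCC)CCC`, 7.3 uM

In a functional assay on HepG2 cells (Homo sapiens) for antiproliferative activity, read by sulforhodamine B assay, with a stated time of 3 days (a lower number here means that less compound is needed, a higher number that more compound is needed for the effect), compound 1 gives 8.3 uM, the higher of the two numbers reported; its nearest neighbour is compound 3, a single change away, and a 1.1-fold lower number from compound 1 to compound 3 (0.06 log units; within the scatter). Compound 2 carries a methoxy group and isopentyl chains in place of the propoxy group and propyl chains of compound 1. In this assay compound 2 is reported as "not active" (no number reported). For the measured compounds named here, it differs from compound 1 in several places, so no single step can be drawn from it.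

Compound 4, `CCCC1=C(OCCC(C)C)C(CCC)(CCC)C(=O)/C(=C(O)\C=C\c2ccccc2)C1=O`, differs from compound 1 in one place: isopropyl in place of methyl on a saturated chain carbon, two bonds along the chain from an oxygen on an unsaturated carbon. Going by the values given here, no measured step touches this position; the one measured step, from compound 1 to compound 3, concerns the aromatic ring and lies within the scatter. The only hint on a longer branched chain comes from compound 2, where it is joined to a change of the alkoxy group and loss of activity. Compound 4 is therefore expected to stay close to compound 1, with a 1.2-fold higher number from compound 1 to compound 4 (0.08 log units; within the scatter) and an estimate of 10 uM, between 4 uM and 30 uM.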

Compound 4, concentration for half-maximal effect: 15.5 uM
Compound 4: the middle estimate sits 1.6-fold (0.19 log units) below what was measured, within the range that was stated.
By their numbers in this assay, from the lowest: compounds 3, 1 and 4 (each within the scatter of the next, the first and the last beyond it).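

With the propyl chains left as they are, isopentyloxy in place of propoxy still gives a number in this assay, and this position now has a measured step of its own: a 1.9-fold higher number from compound 1 to compound 4 (0.27 log units; within the scatter). For the compounds shown here, the only earlier step concerned the aromatic ring, so this is the first sign that the branched, longer alkoxy chain, taken alone, does not abolish activity in this assay. Nothing available explains the result or bears on it.

Going by these compounds, what remains open is which of the several changes in compound 2 goes with its "not active" report. It is also unknown whether a hexyloxy chain, or an amine or carboxylic acid at the end of this chain, would still give a number.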